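The compounds below may be only part of what the source reports. "The series", "measured", "known", "first", "only" and "open" are said of these compounds alone.

Going by the values given here, compound 2 `CCC/C=C/c1cc2ccccc2nc1N` stands at the top of the two numbers measured so far in an assay on HEK-Blue hTLR8 cells for agonist activity at Toll-like receptor 8 (Homo sapiens), read by reporter gene assay and spectrophotometry; a higher number here means that more compound is needed for the effect, a lower number that less compound is needed: compound 2 gives 2670 nM, while its nearest neighbour, compound 1 `C=CCCCc1cc2ccccc2nc1N`, gives 490 nM. Among the compounds with values here, the only measured step, a 5.4-fold higher number from compound 1 to compound 2 (0.74 log units; beyond the scatter), came with pent-1-en-1-yl in place of pent-4-en-1-yl on an aromatic carbon. Compound 3 `CCCCc1cc2ccccc2nc1N` carries the change (butyl in place of pent-1-en-1-yl on an aromatic carbon), so the double bond outside aromatic rings that both measured compounds hold is gone and the chain is one carbon shorter. The measured step bears on this only loosely, since it moved a double bond rather than removing it. Because compound 1 gives 490 nM, a chain that is not pent-1-en-1-yl has already shown a lower number, and the new chain is expected to move back in that direction. The expected step is a 3.8-fold lower number from compound 2 to compound 3 (0.58 log units; beyond the scatter). Compound 3 is estimated at 700 nM, within a range from 250 nM to 2000 nM.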

Compound 3, half-maximal effective concentration: 410 nM
Compound 3: the middle estimate sits 1.7-fold (0.23 log units) above what was measured; the range from low to high includes it.
By their numbers in this assay, from the lowest: compounds 3 and 1 (each within the scatter of the next); then compound 2.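

In this assay, the saturated butyl chain does away with the high number seen with pent-1-en-1-yl (a 6.5-fold lower number from compound 2 to compound 3 (0.81 log units; beyond the scatter)), so a low number at this position does not need a double bond in the chain. Methyl in place of vinyl on a saturated chain carbon, three bonds along the chain from an aromatic carbon, leaves the number within the scatter (a 1.2-fold lower number from compound 1 to compound 3 (0.08 log units; within the scatter)), so among these three compounds only compound 2, with its pent-1-en-1-yl chain, stands apart. No measurement available here explains why that chain gives the higher number.

The change from pent-1-en-1-yl to butyl removes the double bond and shortens the chain at once, so the share of each stays unsettled, and a saturated pentyl chain would separate them. Going by these compounds, whether a longer chain such as hexyl, or a chain ending in an amine, keeps a number like these also remains open.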